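Notes on the series: morpholine for dimethylpyrazole on the aryl amine

The compounds below may be only part of what the source reports. "The series", "measured", "known", "first", "only" and "open" are said of these compounds alone.

Measured so far:
- compound 1 `Cc1ccc(CNC(=O)c2cccc(C(C)Oc3ccnc(Nc4cnn(C)c4)c3)c2)cc1`: 8900 nM
- compound 2 `Cc1ccc(CNC(=O)c2cccc(C(C)Oc3ccnc(Nc4cn(C)nc4C)c3)c2)cc1`: 17500 nM

In a functional assay on HCC78 cells (Homo sapiens) for antiproliferative activity, read by MTT assay, with a stated time of 48 h (a higher number here means a weaker inhibitor, a lower number a stronger inhibitor), compound 1 gives 8900 nM and compound 2 gives 17500 nM. Going by the values given here, compound 2 has the highest of the two numbers, but its only neighbour is compound 1, and the step of a 2.0-fold higher number from compound 1 to compound 2 (0.29 log units; within the scatter) lies within the scatter, so the two stand as alike on these numbers.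

Compound 3 `Cc1ccc(CNC(=O)c2cccc(C(C)Oc3ccnc(NN4CCOCC4)c3)c2)cc1` is not yet measured. Its change from compound 2 is morpholin-4-yl in place of 1,3-dimethyl-1H-pyrazol-4-yl on a nitrogen on an aromatic ring. Among the compounds with values here, the only measured step, from compound 1 to compound 2, concerns a methyl in place of hydrogen on the pyrazole that now leaves altogether, so it does not bear on the exchange of the whole ring; no measured step does. Both measured compounds sit at weak numbers, and the change is a larger one than anything already seen. The expectation for compound 3 is therefore loosely set around compound 2, with a wide range, as a step of a 1.4-fold higher number from compound 2 to compound 3 (0.15 log units; within the scatter). Compound 3 is estimated at 25000 nM in this assay, within 7000 nM to 90000 nM.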

Compound 3, half-maximal inhibitory concentration: 68300 nM
Estimate against measurement, compound 3: 2.7-fold (0.44 log units) below, and the stated range covers the measured number.
By their numbers in this assay, from the lowest: compounds 1 and 2 (each within the scatter of the next); then compound 3.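

In this assay, morpholin-4-yl in place of 1,3-dimethyl-1H-pyrazol-4-yl on this nitrogen gives a 3.9-fold higher number from compound 2 to compound 3 (0.59 log units; beyond the scatter), and the exchange for the 1-methyl-1H-pyrazol-4-yl group gives a 7.7-fold higher number from compound 1 to compound 3 (0.89 log units; beyond the scatter). Going by these compounds alone, this is the first change at this place that reaches beyond the scatter, so exchanging the whole ring moves the number where the added methyl on the pyrazole did not separate compound 1 from compound 2, and the printed counts of hydrogen-bond donors and acceptors for the leaving and entering groups are the same, so those counts do not distinguish the two groups. No measurement is available that would explain the step.

The exchange alters ring size and aromatic character together, so the compounds shown leave open which of the two goes with the higher number; a phenyl ring or a piperidin-1-yl group on the same nitrogen would help to separate them. Also open, on these data alone, is whether any other group at this place, such as a pyridine ring, would give a number clearly lower than that of compound 1, and whether the step seen here would hold on a different core.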